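Swapping 1H-indol-3-yl for 4-bromophenyl on compound 2

The compounds below may be only part of what the source reports. "The series", "measured", "known", "first", "only" and "open" are said of these compounds alone.

For the measured compounds named here, in a functional assay on DU-145 cells (Homo sapiens) for inhibition, read by trypan blue exclusion, with a stated time of 96 h (a lower number here means a stronger inhibitor of growth, a higher number a weaker inhibitor of growth), compound 2 `O=C(/C(=C\c1c[nH]c2ccccc12)SCc1ccc(F)cc1)c1ccc(Cl)cc1` gives 1000 nM, the lower of the only two actual numbers available. Compound 3 `Cc1ccc(S/C(=C/c2c[nH]c3ccccc23)C(=O)c2ccc(Cl)cc2)cc1` gives 10000 nM. Compound 1 `Cc1ccc(S/C(=C/c2ccc(C)s2)C(=O)c2ccc(Br)cc2)cc1`, which carries no 1H-indol-3-yl, is recorded only as a limit, > 100000 nM.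

Compound 4 `O=C(/C(=C\c1ccc(Br)cc1)SCc1ccc(F)cc1)c1ccc(Cl)cc1` has 4-bromophenyl in place of 1H-indol-3-yl on a double-bonded chain carbon bound to a double-bonded chain carbon. Going by the values given here, no measured step covers this change directly. The only one, 4-methylphenyl in place of 4-fluorobenzyl on a sulfur, lies elsewhere in the structure, so a 10-fold higher number from compound 2 to compound 3 (1.00 log units; beyond the scatter) serves only as a guide to size. Taking that size, and the absence of any measured number for compound 1 as a caution, a move of similar scale toward a weaker inhibitor of growth is expected, an estimated 8.0-fold higher number from compound 2 to compound 4 (0.90 log units; beyond the scatter). In this assay, compound 4 is estimated at 8000 nM, with an expected range of 1500 nM to 50000 nM.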

Compound 4, concentration for 50% growth inhibition: 9000 nM
Beside the measured number, compound 4's estimate is 1.1-fold (0.05 log units) below it; the range from low to high includes it.
By their numbers in this assay, from the lowest: compound 2; then compounds 4 and 3 (each within the scatter of the next). At a limit, above all of these: compound 1.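

In this assay, the place on a double-bonded chain carbon bound to a double-bonded chain carbon proves sensitive to its group: replacing 1H-indol-3-yl with 4-bromophenyl gives a 9.0-fold higher number from compound 2 to compound 4 (0.95 log units; beyond the scatter). For the compounds shown here, the earlier step reported only on the group on the sulfur, so this is the first measured change at this position. The swap removes a five-membered aromatic ring and the one hydrogen-bond donor of the group together, and this single step cannot separate the two.

On these data alone, what a 4-aminophenyl or a 1-methylindol-3-yl group would give at this place remains open, and with it whether the hydrogen on the indole nitrogen matters. Compound 1 differs from these compounds in more than one place and offers only a limit, not a number: the limit of > 100000 nM in this assay, at which 1 of the 4 values shown sits.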